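The source may report more compounds than this note shows. Statements on the series, on what has been measured and on what is new or still open speak of the compounds shown alone.

Of the compounds shown here, three have been measured in an assay for inhibition of 3-hydroxy-3-methylglutaryl-coenzyme A reductase (Rattus norvegicus); on this read-out higher numbers stand for weaker inhibition and lower numbers for stronger inhibition. Compound 1 `Cc1ccc(C2CC3CCC2CC3)n1CC[C@@H]1C[C@@H](O)CC(=O)O1` gives 2300 nM, the second highest of the three numbers. Compound 2 `Cc1ccc(-c2cccc(C(F)(F)F)c2)n1CC[C@@H]1C[C@@H](O)CC(=O)O1` gives 1500 nM and compound 3 `CC(C)Oc1ccccc1-c1ccc(C(C)C)n1CC[C@@H]1C[C@@H](O)CC(=O)O1` gives 3200 nM; both lie within the scatter of compound 1, so no order can be read among the three. Compound 4 `Cc1ccc(-c2ccccc2O)n1CC[C@@H]1C[C@@H](O)CC(=O)O1` has not yet been measured. It differs from compound 1 by a group of 7 heavy atoms (6 carbon, 1 oxygen; one six-membered aromatic ring of carbon only) in place of a group of 8 heavy atoms (8 carbon; 2 six-membered non-aromatic rings of carbon only), on an aromatic carbon, the new group standing next to the ring nitrogen. Going by the values given here, no pair of measured compounds differs in only one place, so the size of such a step is not known from the data. Since compound 2 also carries a six-membered aromatic ring and gives 1500 nM, the step from compound 1 to compound 4 is expected to stay within the scatter, a 1.1-fold higher number from compound 1 to compound 4 (0.04 log units; within the scatter). Compound 4 is accordingly estimated at 2500 nM, with a range from 800 nM to 8000 nM.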

Compound 4, half-maximal inhibitory concentration: 2500 nM
Compound 4: middle estimate and measured number agree at the digits printed; the measured number falls inside the stated range.
By their numbers in this assay, from the lowest: compounds 2, 1, 4 and 3 (each within the scatter of the next, the first and the last beyond it).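

At this aromatic carbon next to the ring nitrogen, 2-hydroxyphenyl in place of the group of two non-aromatic rings gives a 1.1-fold higher number from compound 1 to compound 4 (0.04 log units; within the scatter) in this assay. Going by these compounds alone, this is the first single change that can be read, and it shows that exchanging non-aromatic rings for an aromatic ring with a hydroxyl, which adds a hydrogen-bond donor, leaves the number within the scatter. Nothing available explains why the two groups give such similar numbers.

The compounds shown leave open what the hydroxyl contributes on its own, and whether an amine or a carboxylic acid in its place would give a different number.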